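Shifting the Bromine on the Furan Ring

The compounds below may be only part of what the source reports. "The series", "measured", "known", "first", "only" and "open" are said of these compounds alone.

Three compounds share one core and differ only in the group on the furan ring. In a functional assay on DU-145 cells (Homo sapiens) for inhibition, read by MTT assay, with a stated time of 72 h (on this read-out lower numbers stand for stronger inhibition of growth and higher numbers for weaker inhibition of growth), compound 1 `COc1ccc(CNC(=O)/C(C#N)=C/c2ccc(C)o2)cc1` gives 39000 nM, compound 2 `COc1ccc(CNC(=O)/C(C#N)=C/c2ccc(Cl)o2)cc1` gives 12000 nM, and compound 3 `COc1ccc(CNC(=O)/C(C#N)=C/c2ccc(Br)o2)cc1` gives 12000 nM. Compound 3 stands level with compound 2, and together the two show the lowest numbers of the three; the step of a 3.3-fold lower number from compound 1 to compound 3 (0.51 log units; beyond the scatter) lies beyond the scatter, as does a 3.3-fold lower number from compound 1 to compound 2 (0.51 log units; beyond the scatter), while no change at the digits printed from compound 2 to compound 3 (within the scatter) shows no change at the digits printed.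

Compound 4 `COc1ccc(CNC(=O)/C(C#N)=C/c2cc(Br)co2)cc1` carries the same atoms joined differently: 4-bromofuran-2-yl in place of 5-bromofuran-2-yl on a double-bonded chain carbon bound to a double-bonded chain carbon. For the measured compounds named here, none of the measured steps bears directly on this change, since all three measured compounds carry their group as 5-substituted furan; the steps only show that chloro or bromo in that place gives a modest lowering relative to methyl. For compound 4 a step in this assay of a 1.7-fold higher number from compound 3 to compound 4 (0.22 log units; within the scatter) is therefore expected, essentially a guess that the number may drift upward but without a firm basis. Compound 4 is estimated at 20000 nM, within a range from 8000 nM to 50000 nM.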

Compound 4, concentration for 50% growth inhibition: 61000 nM
The estimate for compound 4 lay 3.1-fold (0.48 log units) below the measured number; the measured number lies above the stated range.
By their numbers in this assay, from the lowest: compounds 2 and 3 (each within the scatter of the next); then compounds 1 and 4 (each within the scatter of the next).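

Moving the bromine, with no atom gained or lost, clearly changes the result in this assay: 4-bromofuran-2-yl in place of 5-bromofuran-2-yl gives a 5.1-fold higher number from compound 3 to compound 4 (0.71 log units; beyond the scatter), so where the halogen sits on the furan matters, not just which group is present. The comparison with the chloro compound gives the same picture, with a 5.1-fold higher number from compound 2 to compound 4 (0.71 log units; beyond the scatter), while a 1.6-fold higher number from compound 1 to compound 4 (0.19 log units; within the scatter) shows that the shifted bromo compound cannot be told apart from the methyl compound, so the advantage of bromo over methyl is not retained after the shift. Nothing available here explains why moving the bromine has this effect.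

The compounds shown leave open whether 4-chlorofuran-2-yl would follow 4-bromofuran-2-yl. They also leave open how an amine or a carboxylic acid on the furan would compare with these halogens.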